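Aryl swap on the aromatic nitrogen of the shared core

The source may hold more compounds than are shown below. What is called first, only, known or untested is meant among the compounds shown, and "the series" means these compounds.

Measured so far:
compound 1 `Cn1cc(NC(=O)c2ccc(NS(=O)(=O)c3ccccc3)cc2)cn1` — > 100000 nM, a limit of the assay
compound 2 `Cc1ccc(-n2cc(NC(=O)c3ccc(NS(=O)(=O)c4ccccc4)cc3)cn2)cc1` — 18100 nM

In a functional assay on HepG2 cells (Homo sapiens) for inhibition, read by MTT assay, with a stated time of 48 h (on this read-out lower numbers stand for stronger inhibition and higher numbers for weaker inhibition), compound 2 gives 18100 nM, the only number shown. Within the data shown here, the single measured step is an at least 5.5-fold lower number from compound 1 to compound 2 (0.74 log units; beyond the scatter), with compound 1 sitting at the limit of > 100000 nM in this assay, at which 1 of the 2 values shown sits. Compound 3 `COc1cccc(-n2cc(NC(=O)c3ccc(NS(=O)(=O)c4ccccc4)cc3)cn2)c1` differs from compound 2 by 3-methoxyphenyl in place of 4-methylphenyl on an aromatic nitrogen. Among the measured compounds shown here, no measured step exchanges one aryl for another, so the methyl-to-aryl step bears only loosely on this change. The expectation is no step beyond the scatter, a 1.1-fold lower number from compound 2 to compound 3 (0.05 log units; within the scatter). Compound 3 is estimated at 16000 nM, within 5000 nM to 50000 nM.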

Compound 3, half-maximal inhibitory concentration: 64200 nM
Compound 3: middle estimate off by 4.0-fold (0.60 log units), on the low side, and the stated range ends below it.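

Aryl groups on this aromatic nitrogen are not interchangeable: in this assay, the swap gives a 3.5-fold higher number from compound 2 to compound 3 (0.55 log units; beyond the scatter), so the gain on leaving methyl does not carry equally to every aryl. For 3-methoxyphenyl, the comparison with methyl gives only an at least 1.5-fold lower number from compound 1 to compound 3 (0.19 log units; that floor lies within the scatter), which establishes no difference. Compound 1 gives a limit of the assay, not a number: the limit of > 100000 nM in this assay, at which 1 of the 3 values shown sits.

The substituent and its ring location change together here, leaving open which of them accounts for the step. Unsubstituted phenyl, 4-methoxyphenyl and 3-methylphenyl on this nitrogen remain open.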